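Methyl on the fused ring nitrogen of compound 1

The source may hold more compounds than are shown below. What is called first, only, known or untested is meant among the compounds shown, and "the series" means these compounds.

Compound 1 `COc1ccc(-n2ccc(=O)c(C(=O)Nc3ccc(Oc4ccnc5[nH]ccc45)cc3)n2)cc1` gives 50800 nM in a functional assay on HepG2 cells (Homo sapiens) for cytotoxicity, read by MTT assay, with a stated time of 72 h (on this read-out higher numbers stand for weaker inhibition and lower numbers for stronger inhibition), the highest number of the three measured compounds. Compound 3 `O=C(Nc1ccc(Oc2ccnc3[nH]ccc23)cc1)c1nn(-c2ccccc2)ccc1=O` gives 17800 nM and compound 2 `O=C(Nc1ccc(Oc2ccnc3[nH]ccc23)cc1)c1nn(-c2ccc(Br)cc2)ccc1=O` gives 4280 nM; the steps of a 2.9-fold lower number from compound 1 to compound 3 (0.46 log units; beyond the scatter) and a 12-fold lower number from compound 1 to compound 2 (1.07 log units; beyond the scatter) are both beyond the scatter, as is a 4.2-fold higher number from compound 2 to compound 3 (0.62 log units; beyond the scatter). All three measured steps alter the substituent on an aromatic carbon, while the fused system of the shared core carries an unsubstituted aromatic nitrogen throughout.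

Compound 4 `COc1ccc(-n2ccc(=O)c(C(=O)Nc3ccc(Oc4ccnc5c4ccn5C)cc3)n2)cc1` differs from compound 1 by methyl in place of hydrogen on an aromatic nitrogen. For the measured compounds named here, none of the measured steps touches this part of the shared core, so no step bears directly on it; the measured steps only show that this assay responds to changes elsewhere in the molecule by modest to large amounts. Going by the values given here, with no precedent for this change, the expected step of a 1.0-fold lower number from compound 1 to compound 4 (0.01 log units; within the scatter) is none beyond the scatter, and the range is set wide to allow for a shift in either direction. Compound 4 is therefore estimated at 50000 nM in this assay, within 15000 nM to 160000 nM.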

Compound 4, half-maximal inhibitory concentration: > 60000 nM
Compound 4: a limit, no number (the forecaster's own chance of this, stated with the estimate: 10%); middle value at least 1.2-fold (0.07 log units) from the limit.
By their numbers in this assay, from the lowest: compound 2; then compound 3; then compound 1. At a limit, above all of these: compound 4.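

In this assay, compound 4 carries a limit and not a number: the limit of > 60000 nM in this assay, at which 1 of the 4 values shown sits.

For the compounds shown here, the step reads an at least 1.1-fold higher number from compound 1 to compound 4 (0.07 log units; that floor lies within the scatter), the first reading at this position of the shared core: methyl in place of hydrogen on an aromatic nitrogen of the five-membered aromatic ring gives no lower number than compound 1, and the floor of the step does not establish a rise beyond the scatter. Bromo and hydrogen in place of methoxy on an aromatic carbon both lowered the number from compound 1, whereas this change on the ring nitrogen did not, though the size of any rise remains unknown.

On these data alone, it remains open how far the true number of compound 4 lies past its limit, and whether methyl on this nitrogen would behave in the same way on the bromo compound 2, whose number is much lower and leaves more room for a rise to be read. Also open is how this nitrogen would respond to a longer chain such as ethyl or to a chain ending in an amine, since methyl is the only replacement for hydrogen shown here.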